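Methylsulfanyl in place of ethyl on a benzylamide

The source may report more compounds than this note shows. Statements on the series, on what has been measured and on what is new or still open speak of the compounds shown alone.

Two compounds of this series have been run in a functional assay on the whole organism (strain NMRI) for inhibition, with Mus musculus as the target, in the formalin test, with a stated time of 30 min; a lower number here means that less compound is needed, a higher number that more compound is needed for the effect. Compound 1 `CCC(C)C(N)C(=O)NCc1ccccc1` gives only a limit of the assay in this assay, namely > 22 mg/kg. Compound 2 `CCCC[C@@H](N)C(=O)NCc1ccccc1` likewise gives only a limit of the assay in this assay, namely > 71 mg/kg. Going by the values given here, compound 2 therefore stands without a number of its own: what is known of it is a limit (the limit of > 71 mg/kg in this assay, at which 1 of the 2 values shown sits), and the one further value shown is also a limit (the limit of > 22 mg/kg in this assay, at which 1 of the 2 values shown sits), so no measured step between the two compounds can be drawn.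

The unmeasured compound 3 `CSCC[C@@H](N)C(=O)NCc1ccccc1` differs from compound 2 by methylsulfanyl in place of ethyl on a saturated chain carbon, three bonds along the chain from an amine nitrogen and a carbonyl carbon. With no measured step shown, nothing in these data says what size of step to expect in this assay from this change; the expectation is for none beyond the scatter, in either direction. Compound 3 is therefore expected to land near 80 mg/kg, with a range from 30 mg/kg to 200 mg/kg, and it is likely that this assay again reports only a limit. The step from compound 2 to compound 3 is estimated as a step that the limit leaves unreadable from compound 2 to compound 3.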

Compound 3, dose for half-maximal effect: > 76 mg/kg
Compound 3 was reported as a limit; the forecaster's own chance of this, stated with the estimate: 70%; the middle value is on the limit's open side.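

In this assay compound 3 gives only a limit of the assay, > 76 mg/kg. Compound 2 likewise gives only a limit, > 71 mg/kg. Going by these compounds alone, no step from compound 2 to compound 3 can be read from these two limits. The compounds shown leave open what dose of any of them gives the half-maximal effect, and whether methylsulfanyl in place of ethyl changes that dose at all.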